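The source may report more compounds than this note shows. Statements on the series, on what has been measured and on what is new or still open speak of the compounds shown alone.

Measured in a functional assay on the whole organism with Rattus norvegicus as the target; on this read-out lower numbers stand for an effect already at smaller amounts and higher numbers for an effect only at larger amounts of compound:
- Compound 1 `Cc1cc(Cl)c(NC(=O)N(Cc2ccc(Oc3ccc(F)cc3)cc2)C2CCCCCC2)c(Cl)n1`: > 0.1 mg/kg
- Compound 2 `Cc1cc(C)c(NC(=O)N(Cc2ccc(Oc3ccc(F)cc3)cc2)C2CCCCCC2)c(C)n1`: 0.044 mg/kg
- Compound 3 `COc1nc(C)ccc1NC(=O)N(Cc1ccc(Oc2ccc(F)cc2)cc1)C1CCCCCC1`: > 0.1 mg/kg

Compound 1 stands at the limit of > 0.1 mg/kg in this assay, at which 2 of the 3 values shown sit. This is a limit and not a number, so only compound 2 offers a true value.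

Compound 4 `Cc1ccc(NC(=O)N(Cc2ccc(Oc3ccc(F)cc3)cc2)C2CCCCCC2)c(Cl)n1` differs from compound 1 in one place: hydrogen in place of chloro on an aromatic carbon. Hydrogen replaces chloro on an aromatic carbon, opposite the ring nitrogen.

For the measured compounds named here, no measured step makes this change alone. The nearest evidence is an at least 2.2-fold lower number from compound 1 to compound 2 (0.35 log units; beyond the scatter), where methyl replaces chloro in two places at once, and an at least 2.2-fold higher number from compound 2 to compound 3 (0.35 log units; beyond the scatter), which removes the methyl from that same carbon while also exchanging another group. Compound 3 carries hydrogen on that carbon, as compound 4 does, and it gives only a limit as well. In this assay, compound 4 is therefore expected to stay close to compound 1, with no step beyond the scatter in either direction.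

The estimated step is a step that the limit leaves unreadable from compound 1 to compound 4.

For compound 4 the expected value is 0.15 mg/kg, with an estimated range of 0.05 mg/kg to 0.5 mg/kg.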

Compound 4, dose for half-maximal effect: > 0.1 mg/kg
Compound 4: no number, only a limit; the forecaster's own chance of this, stated with the estimate: 65%; the middle value is on the limit's open side.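

In this assay compound 4 gives > 0.1 mg/kg, which is a limit and not a number. Hydrogen in place of chloro opposite the ring nitrogen leaves compound 4 at the same limit as the others, and the steps to compound 4 from compound 1 and from compound 3 cannot be read: the limit of > 0.1 mg/kg in this assay, at which 3 of the 4 values shown sit. The only readable comparison is an at least 2.2-fold higher number from compound 2 to compound 4 (0.35 log units; beyond the scatter), so taking away that chloro alone does not close the gap to the one true value.

Going by these compounds, how far compound 1, compound 3 and compound 4 lie past their limit stays unknown, so hydrogen against chloro on this carbon has no measured size. On these data alone, whether a single methyl on this carbon, or methyl in place of the remaining chloro, would give a true value stays open, as does what a fluoro or an amine would do there.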